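Shortening the Carbamate Chain: Expected Cytotoxicity of Compound 3

The source may report more compounds than this note shows. Statements on the series, on what has been measured and on what is new or still open speak of the compounds shown alone.

Compound 1 `CCCCOC(=O)Nc1ccc([Se]C#N)cc1` gives 12200 nM in an ADME assay on BEAS-2B cells (Homo sapiens) for cytotoxicity, read by MTT assay, with a stated time of 72 h; on this read-out lower numbers stand for stronger inhibition of growth and higher numbers for weaker inhibition of growth.
Compound 2 `CC(C)COC(=O)Nc1ccc([Se]C#N)cc1` gives 49500 nM in this assay.

Within the data shown here, compound 2 stands at the higher of the two numbers, the only measured step being a 4.1-fold higher number from compound 1 to compound 2 (0.61 log units; beyond the scatter). Compound 3 `C=CCOC(=O)Nc1ccc([Se]C#N)cc1` differs from compound 2 by vinyl in place of isopropyl on a saturated chain carbon bound to an oxygen next to a carbonyl group, which one bond further out reads isobutyl to allyl. Among the measured compounds shown here, only that single step bears on this change, and it runs in the opposite sense, from a straight chain to a branched one. A fall in number toward compound 1 is therefore expected, a 3.3-fold lower number from compound 2 to compound 3 (0.52 log units; beyond the scatter). Compound 3 is estimated at 15000 nM, with a range from 5000 nM to 50000 nM.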

Compound 3, concentration for total growth inhibition: 47400 nM
Estimate against measurement, compound 3: 3.2-fold (0.50 log units) below, and the stated range covers the measured number.
By their numbers in this assay, from the lowest: compound 1; then compounds 3 and 2 (each within the scatter of the next).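

Putting vinyl in place of isopropyl on this saturated chain carbon gives a 1.0-fold lower number from compound 2 to compound 3 (0.02 log units; within the scatter) in this assay, so the branched and the double-bonded chain cannot be told apart here. Vinyl in place of propyl gives a 3.9-fold higher number from compound 1 to compound 3 (0.59 log units; beyond the scatter), so the gap from compound 1 is not confined to branching: it also appears with the double-bonded chain. Nothing shown gives a reason for this pattern.

Going by these compounds, whether a longer chain, a phenyl ring or an amine at this place would read closer to compound 1 or to compound 3 remains open.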